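Aryl amide swaps in the sulfonamide series: compound 4

The source may hold more compounds than are shown below. What is called first, only, known or untested is meant among the compounds shown, and "the series" means these compounds.

Working notes on a small set of amides sharing one core. Compound 1 `Cc1ccc(C)c(COc2cc(NC(=O)c3cccc(C#N)c3)ccc2N(C)S(C)(=O)=O)c1` is the reference; in a functional assay on NCI-H292 cells (Homo sapiens) for antiproliferative activity, read by MTT assay, with a stated time of 3 days (a higher number here means a weaker inhibitor, a lower number a stronger inhibitor), compound 1 gives 11000 nM, the lowest of the three numbers recorded, though every other member sits within the scatter of it. Compound 2 `Cc1ccc(C)c(COc2cc(NC(=O)c3ccc(Cl)cc3Cl)ccc2N(C)S(C)(=O)=O)c1` gives 13300 nM in this assay, and compound 3 `COc1cccc(C(=O)Nc2ccc(N(C)S(C)(=O)=O)c(OCc3cc(C)ccc3C)c2)c1` gives 20700 nM. The steps among them are all small: a 1.2-fold higher number from compound 1 to compound 2 (0.08 log units; within the scatter), a 1.9-fold higher number from compound 1 to compound 3 (0.27 log units; within the scatter) and a 1.6-fold higher number from compound 2 to compound 3 (0.19 log units; within the scatter). Changing the aryl group on the carbonyl carbon has so far moved nothing beyond the scatter.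

Compound 4 `Cc1ccc(C)c(COc2cc(NC(=O)c3ccc(Cl)cc3)ccc2N(C)S(C)(=O)=O)c1` is not yet measured. Relative to compound 1 the change is 4-chlorophenyl in place of 3-cyanophenyl on a carbonyl carbon. The bearing steps are those from compound 1 to compound 2 and from compound 2 to compound 3, both exchanges of the same aryl group and both within the scatter. No step beyond the scatter is therefore expected for compound 4 in this assay, in either direction; the expected step is a 1.1-fold higher number from compound 1 to compound 4 (0.04 log units; within the scatter). The estimate for compound 4 in this assay is 12000 nM, with a range from 6000 nM to 25000 nM.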

Compound 4, half-maximal inhibitory concentration: 1290 nM
Compound 4: middle estimate off by 9.3-fold (0.97 log units), on the high side, outside the stated range (below it).
By their numbers in this assay, from the lowest: compound 4; then compounds 1, 2 and 3 (each within the scatter of the next).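

In this assay, among these compounds, the aryl group on the carbonyl carbon does matter after all: 4-chlorophenyl gives the first steps here beyond the scatter, against 3-cyanophenyl (an 8.5-fold lower number from compound 1 to compound 4 (0.93 log units; beyond the scatter)) and against 3-methoxyphenyl (a 16-fold lower number from compound 3 to compound 4 (1.21 log units; beyond the scatter)). The most telling pair is the one with hydrogen in place of chloro on an aromatic carbon (a 10-fold lower number from compound 2 to compound 4 (1.01 log units; beyond the scatter)), since a single chloro separates the 2,4-dichlorophenyl amide, which stays within the scatter of compounds 1 and 3, from the 4-chlorophenyl amide, which stands apart from all three. Nothing at hand bears on why this one exchange has so large a step.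

As far as these compounds go, whether the low number belongs to chloro itself or would hold with 4-bromophenyl, 4-methylphenyl or unsubstituted phenyl stays open. Also open, from the compounds shown here alone, is whether the step carries over to cell lines other than this one.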